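A few compounds are considered here, and "the series" means these few. Any claim that something is new, unique, unknown or untested is made for them only; others in the source may bear on it.

In a functional assay on MDA-MB-231 cells (Homo sapiens) for cytotoxicity, read by MTT assay, with a stated time of 96 h (on this read-out higher numbers stand for weaker inhibition and lower numbers for stronger inhibition), compound 1 `CC[C@H](N)C(=O)N[C@@H]1C(=O)N2[C@@H](CC[C@@H]1CCNC(=O)NCc1ccccc1)CC[C@H]2C(=O)NC(c1ccccc1)c1ccccc1` gives 10800 nM, and compound 2 `CCNCC[C@H]1CC[C@H]2CC[C@@H](C(=O)NC(c3ccccc3)c3ccccc3)N2C(=O)[C@H]1NC(=O)[C@@H](N)CC` gives 8000 nM, so compound 2 stands level with compound 1 within the scatter. Compound 3 `CC[C@H](N)C(=O)N[C@@H]1C(=O)N2[C@@H](CC[C@@H]1CCNCc1ccccc1)CC[C@H]2C(=O)NC(c1ccccc1)c1ccccc1` carries phenyl in place of methyl on a saturated chain carbon bound to an amine nitrogen. Within the data shown here, the one measured step that bears on this change is a 1.4-fold lower number from compound 1 to compound 2 (0.13 log units; within the scatter), and it lies within the scatter, so no shift beyond the scatter is expected in this assay. The expected step is a 1.1-fold lower number from compound 2 to compound 3 (0.06 log units; within the scatter). The estimated value for compound 3 is 7000 nM, with a range from 2500 nM to 20000 nM.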

Compound 3, half-maximal inhibitory concentration: 400 nM
For compound 3 the middle estimate is 18-fold (1.24 log units) above the measured one, outside the stated range (below it).
By their numbers in this assay, from the lowest: compound 3; then compounds 2 and 1 (each within the scatter of the next).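

In this assay the group on this amine nitrogen proves decisive: phenyl in place of methyl on the saturated chain carbon gives a 20-fold lower number from compound 2 to compound 3 (1.30 log units; beyond the scatter) and benzyl in place of benzylcarbamoyl gives a 27-fold lower number from compound 1 to compound 3 (1.43 log units; beyond the scatter) even though compound 1 and compound 2 stood level within the scatter. Compound 1 carries a phenyl ring too, so the ring alone does not produce the step; the benzylamino form of compound 3 does. Nothing given here accounts for this step. Open, from the compounds shown here alone, is whether a phenethyl or cyclohexylmethyl group on that nitrogen would hold the step, and whether a fluorine or methoxy group on the phenyl ring would alter it.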